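Swapping a hydroxy for a methoxy on compound 1

A few compounds are considered here, and "the series" means these few. Any claim that something is new, unique, unknown or untested is made for them only; others in the source may bear on it.

Compound 1 `COc1cc(C(=O)c2ccc(OC)c(O)c2OC)cc(OC)c1O` gives 4250 nM
Compound 2 `COc1cc(C(=O)c2ccc3c(c2)oc(=O)n3S(C)(=O)=O)cc(OC)c1OC` gives 7950 nM

In a functional assay on SF-268 cells (Homo sapiens) for cytotoxicity, read by sulforhodamine B assay, with a stated time of 48 h (on this read-out lower numbers stand for stronger inhibition of growth and higher numbers for weaker inhibition of growth), compound 1 gives 4250 nM and compound 2 gives 7950 nM, two values within the usual scatter of each other, so neither can be ranked ahead. Compound 3 `COc1ccc(C(=O)c2cc(OC)c(OC)c(OC)c2)c(OC)c1O` differs from compound 1 in one place, with methyl in place of hydrogen on an oxygen on an aromatic ring, hydroxy to methoxy (methyl in place of hydrogen on an oxygen on an aromatic ring). For the measured compounds named here, no measured pair here shows this change, so the expectation is loose. A moderate estimated step of a 2.8-fold lower number from compound 1 to compound 3 (0.45 log units; beyond the scatter) is expected, toward stronger inhibition of growth. For compound 3 the estimate is 1500 nM, with an expected range from 150 nM to 8000 nM.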

Compound 3, concentration for 50% growth inhibition: 21.1 nM
For compound 3 the middle estimate is 71-fold (1.85 log units) above the measured one; measured number outside the range, below it.
By their numbers in this assay, from the lowest: compound 3; then compounds 1 and 2 (each within the scatter of the next).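

In this assay the hydroxy to methoxy change gives a 200-fold lower number from compound 1 to compound 3 (2.30 log units; beyond the scatter) with only one added carbon, so this oxygen is a highly sensitive spot on the core of compound 1. The large step also shows that the free hydroxy at this position is not needed for strong inhibition of growth, and compound 3 keeps its other hydroxy. Nothing available explains the size of this step.

As far as these compounds go, whether methyl is the best group on this oxygen remains open, as ethyl or a longer chain could behave differently. An amine in place of this oxygen, or methyl on the remaining hydroxy of compound 3, would also test how far the effect extends.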